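Compound 3 to compound 4: chloro to bromo

A few compounds are considered here, and "the series" means these few. Any claim that something is new, unique, unknown or untested is made for them only; others in the source may bear on it.

Of the compounds shown here, three have numbers so far in an ADME assay on CCRF-CEM cells (Homo sapiens), read by XTT assay, with a stated time of 72 h; a higher number here means a weaker inhibitor, a lower number a stronger inhibitor. Compound 1 (`O=C1C=CC(=O)C1=C/C=C/c1ccccc1`) gives 4400 nM, compound 2 (`Cc1ccc(C=C2C(=O)C=CC2=O)cc1`) gives 2700 nM and compound 3 (`O=C1C=CC(=O)C1=Cc1ccc(Cl)cc1`) gives 6100 nM. Compound 3 sits within the scatter of compound 1 but is separated from compound 2 by more than the scatter. Within the data shown here, that separation is the one measured step: a 2.3-fold higher number from compound 2 to compound 3 (0.35 log units; beyond the scatter), a modest step for chloro in place of methyl on an aromatic carbon.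

Compound 4 (`O=C1C=CC(=O)C1=Cc1ccc(Br)cc1`) has not yet been measured. Its change is bromo in place of chloro on an aromatic carbon, which is bromo in place of chloro on an aromatic carbon. Among the measured compounds shown here, only a 2.3-fold higher number from compound 2 to compound 3 (0.35 log units; beyond the scatter) bears on this change, and only loosely, since it replaces methyl and no measured pair exchanges chloro for bromo. For the measured compounds named here, with that modest step as the sole guide, no step beyond the scatter is expected in this assay. The estimated step is a 1.1-fold lower number from compound 3 to compound 4 (0.04 log units; within the scatter), and its direction is not firmly expected either way. For compound 4 the expected value is 5500 nM, with an estimated range from 2800 nM to 10000 nM.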

Compound 4, half-maximal inhibitory concentration: 1800 nM
The estimate for compound 4 lay 3.1-fold (0.49 log units) above the measured number; measured number below the stated range.
By their numbers in this assay, from the lowest: compounds 4, 2, 1 and 3 (each within the scatter of the next, the first and the last beyond it).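

In this assay, the exchange of one halogen for the next on an aromatic carbon, para to a group of 8 heavy atoms, is not silent: bromo in place of chloro gives a 3.4-fold lower number from compound 3 to compound 4 (0.53 log units; beyond the scatter) and so moves the number beyond the scatter, although the counted hydrogen-bond donors, acceptors and net charge stay the same. Bromo in place of methyl gives a 1.5-fold lower number from compound 2 to compound 4 (0.18 log units; within the scatter) and leaves compound 2 and compound 4 unresolved, so bromo and methyl cannot be ranked at this position. Read with a 2.3-fold higher number from compound 2 to compound 3 (0.35 log units; beyond the scatter), this sets compound 3 apart from both compound 2 and compound 4, and the chloro result, not a general halogen trend, is what stands out. The compounds shown come with no measurement that bears on this result.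

From the compounds shown here alone, whether the separation of chloro from bromo extends to fluoro, iodo, methoxy or an amine at this position remains open, since three substituents give no trend. Also open, going by these compounds, is whether bromo would behave the same way on the longer chain of compound 1, which carries no substituent on its aromatic ring.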